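The source may report more compounds than this note shows. Statements on the series, on what has been measured and on what is new or still open speak of the compounds shown alone.

Measured so far:
Compound 1 `COc1ccc(Cn2c(O)nc3c(N)ncnc32)cc1` gives 10 uM.
Compound 2 `CCNc1nc(N)c2nc(O)n(Cc3ccccc3)c2n1` gives 1 uM.
Compound 3 `Nc1ncnc2c1nc(Cl)n2Cc1ccccc1` gives > 10 uM.

These numbers come from a functional assay (spleen, spleen) for activation, with Mus musculus as the target; a lower number here means that less compound is needed, a higher number that more compound is needed for the effect. Among the two numbers, compound 2 stands lowest, and the nearest is compound 1, whose number is higher by more than the usual scatter. For compound 3 the assay reports only a limit, not a number (the limit of > 10 uM in this assay, at which 1 of the 3 values shown sits).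

Compound 4 `CCCNc1nc(N)c2nc(O)n(Cc3ccccc3)c2n1` has not yet been measured. It differs from compound 2 in one place: methyl in place of hydrogen on a saturated chain carbon, two bonds along the chain from a nitrogen on an aromatic ring. Going by the values given here, no measured pair shows such a step, so the direction rests on expectation alone. A change this small is expected to move the number little, if at all, so the step from compound 2 to compound 4 is estimated at no change at the digits printed from compound 2 to compound 4 (within the scatter). Compound 4 is therefore expected near 1 uM, between 0.3 uM and 3 uM.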

Compound 4, minimum effective concentration: 0.1 uM
Compound 4: middle estimate off by 10-fold (1.00 log units), on the high side; measured number outside the range, below it.
By their numbers in this assay, from the lowest: compound 4; then compound 2; then compound 1.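

Lengthening ethylamino to propylamino with one methyl gives a 10-fold lower number from compound 2 to compound 4 (1.00 log units; beyond the scatter) in this assay. This shows that the chain on this ring nitrogen is sensitive to size, since a single added carbon moves the number beyond the scatter, something compound 1 and compound 3 could not show because neither differs from compound 2 in one place. Nothing in the data at hand accounts for this step.

On these data alone, whether a butylamino chain would lower the number further or raise it again remains open. So does the effect of a branched isopropylamino group at the same place.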